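A few compounds are considered here, and "the series" means these few. Any claim that something is new, unique, unknown or untested is made for them only; others in the source may bear on it.

Series notes. Compound 1 `O=C(CCCCCCc1ccccc1)c1ncc(C(=O)C(F)(F)F)o1` gives 1820 nM in an assay on HEK-293T cells for inhibition of diacylglycerol lipase-alpha (Homo sapiens), read by colorimetric assay; on this read-out higher numbers stand for weaker inhibition and lower numbers for stronger inhibition. Compound 2 `O=C(CCCCCCc1ccccc1)c1ncc(-c2ccccc2F)o1` reaches only the limit of this assay, > 10000 nM, so no number is known for it. Going by the values given here, the one measured step, an at least 5.4-fold higher number from compound 1 to compound 2 (0.73 log units; beyond the scatter), runs into the limit of > 10000 nM in this assay, at which 1 of the 2 values shown sits, and is therefore only a bound on the loss, not a finished measurement. Compound 3 `COc1ccc(-c2cnc(C(=O)CCCCCCc3ccccc3)o2)cc1` differs from compound 2 by 4-methoxyphenyl in place of 2-fluorophenyl on an aromatic carbon. Among the compounds with values here, no measured step exchanges one aryl ring for another on this carbon; the only step available replaces a (trifluoromethyl)carbonyl with a ring, a different change, so it gives no direct guide to size or direction here. With compound 2 already at the limit, the working assumption is that compound 3 stays near or beyond it. The implied step, a step that the limit leaves unreadable from compound 2 to compound 3, is expected to remain within the scatter. Compound 3 is estimated at 15000 nM, with a range from 5000 nM to 50000 nM.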

Compound 3, half-maximal inhibitory concentration: > 10000 nM
Compound 3 gave a limit, no number (the forecaster's own chance of this, stated with the estimate: 65%); the middle value does not contradict the limit.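

In this assay compound 3 gives only a limit, > 10000 nM, so the step between the two aryl rings cannot be read. With 4-methoxyphenyl in place of (trifluoromethyl)carbonyl on the same aromatic carbon, the result is an at least 5.4-fold higher number from compound 1 to compound 3 (0.73 log units; beyond the scatter), and this too is only a bound on the loss, not a finished size. Two different aryl rings on this carbon, 2-fluorophenyl and 4-methoxyphenyl, now both sit at the limit of the assay: the limit of > 10000 nM in this assay, at which 2 of the 3 values shown sit.

On these data alone, whether any aryl ring on this carbon can give a measurable number remains open, and the order of compound 2 and compound 3 is unknown. Also open, as far as these compounds go, is whether a nitrile or a carboxylic acid on this carbon would give a number on this read-out.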